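Cytotoxicity in the difluorobenzyl pyrimidinone series: amine swap

This account rests on a few compounds, and the source may have more. Where it says the series, first, only, none or still open, it means among the compounds named here.

Compound 1 `CC(C)N(C)c1nc(Cc2c(F)cccc2F)cc(=O)[nH]1` — 85000 nM in an ADME assay on MT4 cells (Homo sapiens) for cytotoxicity, read by MTT assay, with a stated time of 4 days; on this read-out higher numbers stand for lower toxicity in this test and lower numbers for higher toxicity in this test
Compound 2 `Cc1c(Cc2c(F)cccc2F)nc(N(C)C(C)C)[nH]c1=O` — 79000 nM in this assay

Going by the values given here, compound 2 stands with compound 1, the only other measured compound, since a 1.1-fold lower number from compound 1 to compound 2 (0.03 log units; within the scatter). Compound 3 `Cc1c(Cc2c(F)cccc2F)nc(N2CCCCC2)[nH]c1=O` carries the change (piperidin-1-yl in place of isopropyl(methyl)amino on an aromatic carbon). Among the compounds with values here, no measured step touches this amine position: the single step known concerns a methyl on the ring and lies within the scatter, so it neither supports nor contradicts an effect here. With nothing beyond the scatter shown, no step beyond the scatter is expected, that is no change at the digits printed from compound 2 to compound 3 (within the scatter). Compound 3 is estimated at 79000 nM, with a range from 40000 nM to 160000 nM.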

Compound 3, half-maximal cytotoxic concentration: > 78000 nM
Compound 3: only a limit was reported (the forecaster's own chance of this, stated with the estimate: 20%); the middle value lies beyond the limit too.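

No step from compound 2 to compound 3 can be read, since compound 3 is reported only as a limit: the limit of > 78000 nM in this assay, at which 1 of the 3 values shown sits.

The compounds shown leave open whether piperidin-1-yl in place of isopropyl(methyl)amino shifts the number in this assay at all.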